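This account rests on a few compounds, and the source may have more. Where it says the series, first, only, none or still open, it means among the compounds named here.

Of the compounds shown here, three sharing one core have been measured in a physicochemical assay for solubility, read by nephelometry, measured as kinetic solubility, at pH 6.5; on this read-out lower numbers stand for lower solubility and higher numbers for higher solubility. Compound 1 `NCc1csc(NC(=O)c2ccc(Cl)cc2)n1` gives 25 ug/mL. Compound 2 `NCc1csc(NC(=O)c2cnn[nH]2)n1` reaches only a limit of the assay, > 100 ug/mL, so no number is known for it. Compound 3 `NCc1csc(NC(=O)c2ncccn2)n1` likewise sits at a limit, > 100 ug/mL. Compound 2 therefore stands at the upper edge of what this assay reports, a position it shares with one other compound here, as seen in the limit of > 100 ug/mL in this assay, at which 2 of the 3 values shown sit.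

Compound 4 `NCc1csc(NC(=O)c2ccn[nH]2)n1` has not yet been measured. It differs from compound 2 in a single place: 1H-pyrazol-5-yl in place of 1H-1,2,3-triazol-5-yl on a carbonyl carbon. Among the compounds with values here, no measured step between two compounds of this set corresponds to that change, so its size can only be estimated.

The ring that enters carries one hydrogen-bond acceptor fewer than the one that leaves, and the expected result is a small downward step, though one that may still be lost inside the limit. Compound 4 is expected to give about 90 ug/mL, within 40 ug/mL to 200 ug/mL, an estimated step of an at least 1.1-fold lower number from compound 2 to compound 4 (0.04 log units; that floor lies within the scatter).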

Compound 4, solubility: > 100 ug/mL
Compound 4 was reported as a limit (the forecaster's own chance of this, stated with the estimate: 45%); middle value at least 1.1-fold (0.04 log units) away from the limit.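

In this assay, compound 2 and compound 4 both sit at a limit, so no step can be read between them: the limit of > 100 ug/mL in this assay, at which 3 of the 4 values shown sit.

The compounds shown leave open whether placing 1H-pyrazol-5-yl in place of 1H-1,2,3-triazol-5-yl changes the solubility at all, since neither compound has an actual number.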